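This account rests on a few compounds, and the source may have more. Where it says the series, first, only, none or still open, it means among the compounds named here.

Compound 1 `COc1cc(N(C)CCN(C)C)c(NC(=O)/C=C\C(C)C)cc1Nc1nc2c(c(-c3cn(C)c4ccc(F)cc34)n1)CSCC2` and compound 2 `CCC/C=C\C(=O)Nc1cc(Nc2nc3c(c(-c4cn(C)c5ccc(F)cc45)n2)CSCC3)c(OC)cc1N(C)CCN(C)C` share one core and differ in a single spot: propyl in place of isopropyl on a double-bonded chain carbon bound to a double-bonded chain carbon. In a functional assay on A549 cells (Homo sapiens) for inhibition, read by MTT assay, with a stated time of 72 h (a higher number here means a weaker inhibitor, a lower number a stronger inhibitor), compound 1 gives 1150 nM, and compound 2 gives 5190 nM, which is a 4.5-fold higher number from compound 1 to compound 2 (0.65 log units; beyond the scatter). Compound 3 `COc1cc(N(C)CCN(C)C)c(NC(=O)/C=C\C(C)C)cc1Nc1nc2c(c(-c3cn(C)c4ccc(F)cc34)n1)CS(=O)(=O)CC2` carries a different core; how its core differs from that of compound 1 is not broken down here. In this assay compound 3 gives 3750 nM, a number that sits between the other two, within the scatter of compound 2 and beyond the scatter of compound 1. Compound 4 `CCC/C=C\C(=O)Nc1cc(Nc2nc3c(c(-c4cn(C)c5ccc(F)cc45)n2)CS(=O)(=O)CC3)c(OC)cc1N(C)CCN(C)C` has the core of compound 3 and, relative to it, the same change seen between compound 1 and compound 2: propyl in place of isopropyl on a double-bonded chain carbon bound to a double-bonded chain carbon. Since that change has been measured only once, the expectation for compound 4 rests on that single step. The step from compound 3 to compound 4 is expected to be about a 3.7-fold higher number from compound 3 to compound 4 (0.57 log units; beyond the scatter), because the matching step was a 4.5-fold higher number from compound 1 to compound 2 (0.65 log units; beyond the scatter). Compound 4 is therefore estimated at 14000 nM in this assay. Given the uncertainty of carrying one step across cores, the value of compound 4 is expected to fall within a span estimated to run from 5500 nM to 36000 nM.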

Compound 4, half-maximal inhibitory concentration: 7570 nM
Estimate against measurement, compound 4: 1.8-fold (0.27 log units) above, within the range that was stated.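

In this assay, putting propyl in place of isopropyl on the core of compound 3 gives a 2.0-fold higher number from compound 3 to compound 4 (0.31 log units; beyond the scatter), so the number goes up on both cores, which means a weaker inhibitor each time. When the two steps are set side by side, the gap between their sizes is no larger than repeated measurements could produce: the same change on two cores in this assay, a 4.5-fold higher number (0.65 log units; beyond the scatter) from compound 1 to compound 2 and a 2.0-fold higher number (0.31 log units; beyond the scatter) from compound 3 to compound 4, 2.2-fold (0.35 log units) apart, within the scatter of two such steps This shows that the change carried over from one core to the other in direction and, within that scatter, in size, but it does not prove that the two steps are equal, it rests on only two pairs of compounds, and it does not explain why propyl gives the higher number.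

Going by these compounds, it remains open whether a shorter chain such as ethyl, a longer chain such as butyl, or a small ring such as cyclopropyl on that double-bonded chain carbon would move the number the same way on both cores. On these data alone, an amine or a hydroxyl group in that place is equally open.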